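The source may hold more compounds than are shown below. What is called first, only, known or untested is meant among the compounds shown, and "the series" means these compounds.

Three relatives sharing one core have been tested in a functional assay on the whole organism with Canis familiaris (Canis lupus familiaris) as the target; on this read-out lower numbers stand for an effect already at smaller amounts and higher numbers for an effect only at larger amounts of compound. There, compound 1 (`COC(=O)CC/C=C\CC[C@H]1C(=O)C[C@@H](O)[C@@H]1/C=C/C[C@@](C)(O)/C=C/C=C(C)C`) gives 0.00006 mg/kg, compound 2 (`C=C/C=C/[C@](C)(O)C/C=C/[C@H]1[C@H](O)CC(=O)[C@@H]1CC/C=C\CCC(=O)OC`) gives 0.000007 mg/kg and compound 3 (`C=C/C(C)=C/[C@](C)(O)C/C=C/[C@H]1[C@H](O)CC(=O)[C@@H]1CC/C=C\CCC(=O)OC`) gives 0.00071 mg/kg. Compound 3 thus holds the highest number of the three, while the other two are separated by an 8.6-fold lower number from compound 1 to compound 2 (0.93 log units; beyond the scatter).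

Compound 4 (`C/C=C/C=C/[C@](C)(O)C/C=C/[C@H]1[C@H](O)CC(=O)[C@@H]1CC/C=C\CCC(=O)OC`) has the same atoms as compound 3, joined differently: penta-1,3-dien-1-yl in place of 2-methylbuta-1,3-dien-1-yl on a saturated chain carbon bound to an oxygen on a saturated carbon and two saturated chain carbons. Penta-1,3-dien-1-yl takes the place of 2-methylbuta-1,3-dien-1-yl on a saturated chain carbon bound to an oxygen on a saturated carbon and two saturated chain carbons, so the branching methyl of compound 3 is gone.

Within the data shown here, no measured step makes exactly this exchange, but two bear on it. Compound 2 and compound 1 also lack that methyl, and the steps to compound 3 are a 100-fold higher number from compound 2 to compound 3 (2.01 log units; beyond the scatter) and a 12-fold higher number from compound 1 to compound 3 (1.07 log units; beyond the scatter). Both are large and point the same way, so a large fall in this assay is expected, with compound 4 landing near compound 1 and compound 2. The expected change is a 36-fold lower number from compound 3 to compound 4 (1.55 log units; beyond the scatter). Compound 4 is estimated at 0.00002 mg/kg, with an expected range from 0.000004 mg/kg to 0.00012 mg/kg.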

Compound 4, dose for half-maximal effect: 0.00003 mg/kg
Estimate against measurement, compound 4: 1.5-fold (0.18 log units) below, within the range that was stated.
By their numbers in this assay, from the lowest: compound 2; then compounds 4 and 1 (each within the scatter of the next); then compound 3.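

With the same five carbons in the leaving and entering groups, the exchange of 2-methylbuta-1,3-dien-1-yl for penta-1,3-dien-1-yl gives a 24-fold lower number from compound 3 to compound 4 (1.37 log units; beyond the scatter) in this assay, so at this position the read-out depends on how these carbons are joined and not only on how many there are. The end of the diene chain is more forgiving among these compounds: extending vinyl to prop-1-en-1-yl gives only a 4.3-fold higher number from compound 2 to compound 4 (0.63 log units; beyond the scatter) and is a modest step, whereas the branched group of compound 3 gives the largest number of the series. Adding a further methyl at that end, as in 2-methylprop-1-en-1-yl, shows no separable effect, with a 2.0-fold lower number from compound 1 to compound 4 (0.30 log units; within the scatter).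

The compounds shown leave open how a phenyl ring or a longer chain, such as hepta-1,3-dien-1-yl, would read at this position. Among these compounds, they also leave open whether a methyl on the chain in other places would carry the same penalty as the one in compound 3. No accompanying measurement offers an explanation for any of these differences.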